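This account rests on a few compounds, and the source may have more. Where it says the series, first, only, none or still open, it means among the compounds named here.

Compound 1 `CN1CCN(c2nc3ccccc3n2CCOc2ccccc2)CC1` is one of three close relatives tested in a functional assay on ileum for inhibition of histamine H1 receptor (Cavia porcellus); a lower number here means a stronger inhibitor, a higher number a weaker inhibitor. In this assay compound 1 gives 6.9 nM, the lowest of the three numbers, though compound 2 `CN1CCCN(c2nc3ccccc3n2CCOc2ccccc2)CC1` with 9.1 nM and compound 3 `CCCCCN1CCCN(c2nc3ccccc3n2CCOCC)CC1` with 7.4 nM both sit within the scatter of it. Within the data shown here, the only single-point step measured so far, a 1.3-fold higher number from compound 1 to compound 2 (0.12 log units; within the scatter), swapped the ring on the aromatic carbon and left the number essentially unchanged. Compound 4 `CC(C)CCn1c(N2CCN(C)CC2)nc2ccccc21` has not been measured; it differs from compound 1 by isopropyl in place of phenoxy on a saturated chain carbon, two bonds along the chain from an aromatic nitrogen. No measured step touches that part of the chain, so nothing shown predicts the direction. Compound 4 is expected to give about 15 nM, within 5 nM to 50 nM. The expected step, a 2.2-fold higher number from compound 1 to compound 4 (0.34 log units; beyond the scatter), is a modest weakening.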

Compound 4, half-maximal inhibitory concentration: 1400 nM
For compound 4 the middle estimate is 93-fold (1.97 log units) below the measured one; the whole stated range lies below it.
By their numbers in this assay, from the lowest: compounds 1, 3 and 2 (each within the scatter of the next); then compound 4.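

In this assay, among these compounds, this part of the chain matters far more than the earlier compounds could show: isopropyl in place of phenoxy gives a 200-fold higher number from compound 1 to compound 4 (2.31 log units; beyond the scatter), a large loss of inhibition. The change removes both the oxygen and the six-membered aromatic ring, so this single step cannot show which of them counts, or whether the smaller size of the group does. Nothing available explains the loss. A phenyl group in the same place would keep the aromatic ring without the oxygen, whereas a cyclohexyloxy group would keep the oxygen without the aromatic ring. On these data alone, how either would fare remains open.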